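Hydroxy in place of fluoro on the aryl hydrazone

A few compounds are considered here, and "the series" means these few. Any claim that something is new, unique, unknown or untested is made for them only; others in the source may bear on it.

Measured so far:
compound 1 `C/C(=N\NC(=O)c1cccc(S(=O)(=O)N2CCOCC2)c1)c1ccc(F)cc1` — > 100000 nM
compound 2 `C/C(=N\NC(=O)c1cccc(S(=O)(=O)N2CCOCC2)c1)c1ccccc1O` — 1220 nM
compound 3 `C/C(=N\NC(=O)c1cccc(S(=O)(=O)N2CCOCC2)c1)c1cccc(O)c1` — > 100000 nM

In a functional assay on EC9706 cells (Homo sapiens) for antiproliferative activity, read by MTT assay, with a stated time of 72 h (on this read-out higher numbers stand for weaker inhibition and lower numbers for stronger inhibition), compound 1 sits at a limit of the assay and gives no number. Compound 3 sits at the same limit. Among the measured compounds shown here, compound 2 is the one member of the series with a measured number in this assay.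

The unmeasured compound 4 `C/C(=N\NC(=O)c1cccc(S(=O)(=O)N2CCOCC2)c1)c1ccc(O)cc1` differs from compound 1 in one place: hydroxy in place of fluoro on an aromatic carbon. For the measured compounds named here, two measured steps bear on it, both placing a hydroxy on the same aryl ring in place of the fluoro. The step of an at least 81-fold lower number from compound 1 to compound 2 (1.91 log units; beyond the scatter) is large; the step that the two limits leave unreadable from compound 1 to compound 3 cannot be read, as both compounds sit at the limit of > 100000 nM in this assay, at which 2 of the 3 values shown sit. Between the two hydroxy compounds, an at least 81-fold higher number from compound 2 to compound 3 (1.91 log units; beyond the scatter) shows that where the hydroxy sits decides the outcome. Going by the values given here, for the 4-hydroxyphenyl there is no measured step, so the expectation is open between the two outcomes already seen.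

Compound 4 is expected to come in at 40000 nM, within 3000 nM to 150000 nM. The step of an at least 2.5-fold lower number from compound 1 to compound 4 (0.39 log units; beyond the scatter) is the estimated result, with a real chance that compound 4 reports only a limit.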

Compound 4, half-maximal inhibitory concentration: 71400 nM
Estimate against measurement, compound 4: 1.8-fold (0.25 log units) below; low and high end bracket the measured number.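

In this assay, the series now has a number for a second hydroxy placement on the aryl ring, and it lies far from the value of the 2-hydroxyphenyl: a 59-fold higher number from compound 2 to compound 4 (1.77 log units; beyond the scatter). At the place para to a large group, the exchange of fluoro for hydroxy gives an at least 1.4-fold lower number from compound 1 to compound 4 (0.14 log units; that floor lies within the scatter), and the move of the hydroxy from the 3-hydroxyphenyl to the 4-hydroxyphenyl gives an at least 1.4-fold lower number from compound 3 to compound 4 (0.14 log units; that floor lies within the scatter); both are floors set by a limit, so neither shows a real gain, and neither rules one out. A hydroxy on this ring is therefore not enough by itself for strong inhibition, and among the four compounds only compound 2, whose steps to all the others are beyond the scatter, stands apart.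

As far as these compounds go, whether a methoxy or an amino group in place of the hydroxy of compound 2 would keep its value stays open. Also open is how far compound 1 and compound 3 lie past the limit, and so how large the two floors above really are: the limit of > 100000 nM in this assay, at which 2 of the 4 values shown sit.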